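Acetyl to Propanoyl on a Piperidine Sulfonamide in Mice

The source may hold more compounds than are shown below. What is called first, only, known or untested is meant among the compounds shown, and "the series" means these compounds.

Compound 1 `CC(=O)N1CCC(NS(=O)(=O)c2ccc(F)cc2)CC1` gives 0.1 mg/kg in a functional assay on the whole organism with Mus musculus as the target, with a stated time of 30 min (on this read-out lower numbers stand for an effect already at smaller amounts and higher numbers for an effect only at larger amounts of compound), the lower of the two numbers recorded so far. Compound 2 `CC(=O)N1CCCC(NS(=O)(=O)c2ccc(F)cc2)C1` gives 1 mg/kg in this assay, a difference that lies beyond the usual scatter. Compound 3 `CCC(=O)N1CCC(NS(=O)(=O)c2ccc(F)cc2)CC1` is not yet measured. It differs from compound 1 by methyl in place of hydrogen on a saturated chain carbon bound to a carbonyl carbon. Within the data shown here, no measured pair shows this change, so the writer expects a step of a 1.5-fold higher number from compound 1 to compound 3 (0.18 log units; within the scatter) that stays within the scatter, in either direction. Compound 3 is expected to give 0.15 mg/kg, with a range from 0.05 mg/kg to 0.5 mg/kg.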

Compound 3, minimum effective dose: 10 mg/kg
Beside the measured number, compound 3's estimate is 67-fold (1.82 log units) below it; measured number above the stated range.
By their numbers in this assay, from the lowest: compound 1; then compound 2; then compound 3.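

In this assay, the acetyl group of compound 1 proves highly sensitive to extension: methyl in place of hydrogen on a saturated chain carbon bound to a carbonyl carbon brings a 100-fold higher number from compound 1 to compound 3 (2.00 log units; beyond the scatter) for a single added carbon. This position therefore tolerates very little growth in the form tested, which the earlier pair could not show. Nothing measured here accounts for the size of this step.

On these data alone, whether a longer chain, a cyclopropyl group or an amine at this place would restore or further reduce the effect remains open. Also open, as far as these compounds go, is whether the same change on the core of compound 2 would give a step of similar size.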